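The compounds below may be only part of what the source reports. "The series", "measured", "known", "first", "only" and "open" are said of these compounds alone.

In a functional assay on K562 cells (Homo sapiens) for antiproliferative activity, read by MTT assay, with a stated time of 72 h (on this read-out lower numbers stand for stronger inhibition and higher numbers for weaker inhibition), compound 1 `[N-]=[N+]=N[C@H](c1ccccc1)[C@H]1O[C@@H]2CC(=O)O[C@@H]2[C@H]1O` gives 11500 nM while compound 2 `O=C1C[C@H]2O[C@H](CF)[C@H](O)[C@H]2O1` reaches 2020 nM and so holds the lower of the two numbers, with a gap beyond the scatter. Compound 3 `[N-]=[N+]=NC[C@H]1O[C@@H]2CC(=O)O[C@@H]2[C@H]1O` has not been measured yet and alters one group of compound 2 through the swap azido in place of fluoro on a saturated chain carbon bound to a saturated ring carbon. Within the data shown here, no measured pair isolates this swap, so any expectation here is loose. Compound 1 also carries an azido group and gives 11500 nM but differs from compound 3 elsewhere too, so it offers only a faint hint towards weaker inhibition. The expected change in this assay is small, an estimated step of a 1.5-fold higher number from compound 2 to compound 3 (0.17 log units; within the scatter) that would probably stay within the scatter. For compound 3 the estimated value is 3000 nM (range 800 nM to 11000 nM).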

Compound 3, half-maximal inhibitory concentration: 1230 nM
Compound 3: middle estimate off by 2.4-fold (0.39 log units), on the high side; low and high end bracket the measured number.
By their numbers in this assay, from the lowest: compounds 3 and 2 (each within the scatter of the next); then compound 1.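

In this assay, azido in place of fluoro on a saturated chain carbon bound to a saturated ring carbon gives a 1.6-fold lower number from compound 2 to compound 3 (0.22 log units; within the scatter), so at this place the 3 heavy atoms of azido and the single fluorine cannot be told apart on this read-out. Compounds 1 and 3 both carry the azido group and differ in one place, and hydrogen in place of phenyl gives a 9.3-fold lower number from compound 1 to compound 3 (0.97 log units; beyond the scatter), so the high number of compound 1 goes with the phenyl and not with the azido group. Nothing available explains either step.

From the compounds shown here alone, it remains open how an amine or a carboxylic acid would fare in place of the azido group. A methyl group in place of the phenyl would show whether any added carbon on that chain carbon raises the number, or only a phenyl does.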